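From 2,3-dimethylphenyl to 2,5-dimethylphenyl on a sulfonamide nitrogen

A few compounds are considered here, and "the series" means these few. Any claim that something is new, unique, unknown or untested is made for them only; others in the source may bear on it.

- compound 1 (`Cc1ccc(NS(=O)(=O)c2ccc(N3CCNC3=O)cc2)cc1C`) gives 230 nM
- compound 2 (`O=C1NCCN1c1ccc(S(=O)(=O)Nc2ccc(F)c(F)c2)cc1`) gives 350 nM
- compound 3 (`Cc1cccc(NS(=O)(=O)c2ccc(N3CCNC3=O)cc2)c1C`) gives 190 nM

These three values come from a functional assay on HT-29 cells (Homo sapiens) for antiproliferative activity, read by sulforhodamine B assay, with a stated time of 48 h (on this read-out higher numbers stand for weaker inhibition and lower numbers for stronger inhibition), and the compounds differ only in the group on the sulfonamide nitrogen. Compound 3 cannot be separated from the other two, with a 1.2-fold lower number from compound 1 to compound 3 (0.08 log units; within the scatter) and a 1.8-fold lower number from compound 2 to compound 3 (0.27 log units; within the scatter). The unmeasured compound 4 (`Cc1ccc(C)c(NS(=O)(=O)c2ccc(N3CCNC3=O)cc2)c1`) carries 2,5-dimethylphenyl in place of 2,3-dimethylphenyl on a sulfonamide nitrogen, and the two groups compare as follows: 2,5-dimethylphenyl in place of 2,3-dimethylphenyl on a sulfonamide nitrogen. The closest evidence is the exchange of one dimethylphenyl group for another, a 1.2-fold lower number from compound 1 to compound 3 (0.08 log units; within the scatter). Even the change to 3,4-difluorophenyl gave only a 1.5-fold higher number from compound 1 to compound 2 (0.18 log units; within the scatter). None of these steps leaves the scatter, so no step beyond the scatter is expected in this assay, and the data favour no direction. The expected step is a 1.2-fold higher number from compound 3 to compound 4 (0.06 log units; within the scatter). For compound 4 the estimate is 220 nM, with an expected range from 110 nM to 440 nM.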

Compound 4, half-maximal inhibitory concentration: 46 nM
The estimate for compound 4 lay 4.8-fold (0.68 log units) above the measured number; the whole stated range lies above it.
By their numbers in this assay, from the lowest: compound 4; then compounds 3, 1 and 2 (each within the scatter of the next).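

In this assay the exchange of 2,3-dimethylphenyl for 2,5-dimethylphenyl on the sulfonamide nitrogen gives a 4.1-fold lower number from compound 3 to compound 4 (0.62 log units; beyond the scatter) even though the two groups hold the same atoms, so this position responds to how the same two methyl groups are arranged on the ring, which no earlier step had shown. Among these compounds, compound 4 also stands apart from the other two groups, with a 5.0-fold lower number from compound 1 to compound 4 (0.70 log units; beyond the scatter) and a 7.6-fold lower number from compound 2 to compound 4 (0.88 log units; beyond the scatter) while every step among the earlier compounds stayed within the scatter. The flat picture given by compound 1, compound 2 and compound 3 therefore does not extend to this one arrangement.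

Going by these compounds, it remains open whether the result holds with a methoxy group, a chlorine or a carboxylic acid in place of the methyl groups of compound 4. Nothing shown here accounts for the difference between these two dimethylphenyl groups.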